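From Fluoro to Cyano: What to Expect for Compound 3

The compounds below may be only part of what the source reports. "The series", "measured", "known", "first", "only" and "open" are said of these compounds alone.

Two compounds share one core. Compound 1 `CC(=O)/C(=N\c1ccccc1)NNc1ccccc1C` carries hydrogen where compound 2 `CC(=O)/C(=N\c1cccc(F)c1)NNc1ccccc1C` carries fluoro. In an assay on isolated protein for binding affinity to corticotropin-releasing factor receptor 1 (Homo sapiens) (on this read-out higher numbers stand for weaker inhibition and lower numbers for stronger inhibition), compound 1 gives 526 nM and compound 2 gives 43 nM; that exchange produced a 12-fold lower number from compound 1 to compound 2 (1.09 log units; beyond the scatter). Compound 2 therefore stands lowest of the two numbers, with compound 1 as its nearest neighbour. Compound 3 `CC(=O)/C(=N\c1cccc(C#N)c1)NNc1ccccc1C` differs from compound 2 by cyano in place of fluoro on an aromatic carbon. Going by the values given here, only the step from compound 1 to compound 2 bears on this position, and it was large, yet it involved fluoro rather than cyano. For compound 3 a small step of a 1.3-fold higher number from compound 2 to compound 3 (0.11 log units; within the scatter) in this assay is expected, with an estimated 55 nM ranging from 12 nM to 250 nM.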

Compound 3, inhibition constant: > 10000 nM
Compound 3: a limit, no number; the forecaster's own chance of this, stated with the estimate: 2%; at least 180-fold (2.25 log units) between middle value and limit.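

Compound 3 gives only a limit of the assay, not a number: the limit of > 10000 nM in this assay, at which 1 of the 3 values shown sits. Replacing fluoro with cyano gives an at least 230-fold higher number from compound 2 to compound 3 (2.36 log units; beyond the scatter), and replacing the original hydrogen with cyano gives an at least 19-fold higher number from compound 1 to compound 3 (1.27 log units; beyond the scatter). This position can therefore move the read-out strongly in either direction, and the gain seen with fluoro does not carry over to cyano.

On these data alone, whether chloro, methoxy or an amine at this position would behave more like fluoro or more like cyano remains open. The compounds shown also cannot explain why cyano behaves so differently from fluoro.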